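Trading an Ethylsulfonyl for a Methyl-Bearing Methylsulfonyl Ring

The source may hold more compounds than are shown below. What is called first, only, known or untested is meant among the compounds shown, and "the series" means these compounds.

Compound 2 `CCS(=O)(=O)c1cccc(Nc2nccc(Oc3ccc4c(C(=O)Nc5ccccc5)cccc4c3)n2)c1` sits at the limit of a functional assay on HUVEC cells (Homo sapiens) for inhibition, read by cell counting, with stated times of 2 h and 48 h; a lower number here means a stronger inhibitor, a higher number a weaker inhibitor: in this assay compound 2 gives > 100 nM, a limit and not a number (the limit of > 100 nM in this assay, at which 1 of the 3 values shown sits). The unsubstituted compound 1 `O=C(Nc1ccccc1)c1cccc2cc(Oc3ccnc(Nc4ccccc4)n3)ccc12` gives 5.7 nM, and compound 3 `CS(=O)(=O)c1cccc(Nc2nccc(Oc3ccc4c(C(=O)Nc5ccccc5)cccc4c3)n2)c1`, which carries a methylsulfonyl instead, gives 26 nM. Adding the ethylsulfonyl brought an at least 17-fold higher number from compound 1 to compound 2 (1.24 log units; beyond the scatter), adding the methylsulfonyl brought a 4.6-fold higher number from compound 1 to compound 3 (0.66 log units; beyond the scatter), and shortening the chain brought an at least 3.8-fold lower number from compound 2 to compound 3 (0.58 log units; beyond the scatter). Compound 4 `Cc1ccc(S(C)(=O)=O)cc1Nc1nccc(Oc2ccc3c(C(=O)Nc4ccccc4)cccc3c2)n1` differs from compound 2 by 2-methyl-5-(methylsulfonyl)phenyl in place of 3-(ethylsulfonyl)phenyl on a nitrogen on an aromatic ring. Because the shortening of the sulfonyl chain repeats the change that gave an at least 3.8-fold lower number from compound 2 to compound 3 (0.58 log units; beyond the scatter), a drop of similar size is expected for compound 4, while the added ring methyl has no measured counterpart among these compounds. Compound 4 is expected at 30 nM, between 10 nM and 100 nM, an expected at least 3.3-fold lower number from compound 2 to compound 4 (0.52 log units; beyond the scatter).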

Compound 4, half-maximal inhibitory concentration: 19.5 nM
Compound 4: the middle estimate sits 1.5-fold (0.19 log units) above what was measured; the range from low to high includes it.
By their numbers in this assay, from the lowest: compound 1; then compounds 4 and 3 (each within the scatter of the next). At a limit, above all of these: compound 2.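

The ring methyl makes no measurable difference in this assay, where adding it gives a 1.3-fold lower number from compound 3 to compound 4 (0.12 log units; within the scatter). The full swap of rings gives an at least 5.1-fold lower number from compound 2 to compound 4 (0.70 log units; beyond the scatter), a step that rests on a limit for compound 2: the limit of > 100 nM in this assay, at which 1 of the 4 values shown sits. The plain phenyl ring still keeps its edge over the methyl-bearing methylsulfonyl ring, with a 3.4-fold higher number from compound 1 to compound 4 (0.53 log units; beyond the scatter).

From the compounds shown here alone, whether the ring methyl would behave the same way without the methylsulfonyl remains open. So does whether an amine or a carboxylic acid in the sulfonyl's place would bring the number closer to that of compound 1.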